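Shifting the Nitro Group: From Compound 3 to Compound 4

The source may hold more compounds than are shown below. What is called first, only, known or untested is meant among the compounds shown, and "the series" means these compounds.

Measured so far:
Compound 1, `Brc1ccc(CSc2nnc(-c3ccncc3)n2-c2ccccc2)cc1`: 12600 nM
Compound 2, `Fc1cccc(F)c1CSc1nnc(-c2ccncc2)n1-c1ccccc1`: > 50000 nM
Compound 3, `O=[N+]([O-])c1cccc(CSc2nnc(-c3ccncc3)n2-c2ccccc2)c1`: 18300 nM

In a functional assay on MCF7 cells (Homo sapiens) for inhibition, read by MTT assay, with a stated time of 48 h (on this read-out higher numbers stand for weaker inhibition and lower numbers for stronger inhibition), compound 3 gives 18300 nM, the higher of the two numbers. Its nearest neighbour is compound 1, with a 1.5-fold higher number from compound 1 to compound 3 (0.16 log units; within the scatter). For compound 2 the assay reports only a limit, > 50000 nM, and an at least 2.7-fold lower number from compound 2 to compound 3 (0.43 log units; beyond the scatter).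

Compound 4, `O=[N+]([O-])c1ccc(CSc2nnc(-c3ccncc3)n2-c2ccccc2)cc1`, differs from compound 3 only in the group on the saturated chain carbon bound to a sulfur: 4-nitrophenyl in place of 3-nitrophenyl on a saturated chain carbon bound to a sulfur. Within the data shown here, none of the measured steps compares two nitrophenyl groups, so no step speaks directly to this change; the swaps that were measured ran between different substituents, and the closest, a 1.5-fold higher number from compound 1 to compound 3 (0.16 log units; within the scatter), stayed within the scatter. For compound 4 a step of a 1.2-fold lower number from compound 3 to compound 4 (0.09 log units; within the scatter) is therefore expected, within the scatter. Compound 4 is estimated at 15000 nM, between 6000 nM and 45000 nM.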

Compound 4, half-maximal inhibitory concentration: 22800 nM
Beside the measured number, compound 4's estimate is 1.5-fold (0.18 log units) below it, within the range that was stated.
By their numbers in this assay, from the lowest: compounds 1, 3 and 4 (each within the scatter of the next). At a limit, above all of these: compound 2.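

The swap of 3-nitrophenyl for 4-nitrophenyl gives a 1.2-fold higher number from compound 3 to compound 4 (0.10 log units; within the scatter), so at this place the two nitrophenyl groups cannot be told apart. Nitro in place of bromo on an aromatic carbon gives a 1.8-fold higher number from compound 1 to compound 4 (0.26 log units; within the scatter), so these two cannot be told apart either. With 2,6-difluorophenyl the reading is only a limit, and 4-nitrophenyl in its place gives an at least 2.1-fold lower number from compound 2 to compound 4 (0.34 log units; beyond the scatter), a step that rests on that limit: the limit of > 50000 nM in this assay, at which 1 of the 4 values shown sits.

As far as these compounds go, whether an amine, a carboxylic acid or a longer chain on this saturated carbon would move the number beyond the scatter stays open.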